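The source may report more compounds than this note shows. Statements on the series, on what has been measured and on what is new or still open speak of the compounds shown alone.

Measured so far in an assay on isolated protein for inhibition of dual specificity protein phosphatase 3 (Homo sapiens); a lower number here means a stronger inhibitor, a higher number a weaker inhibitor:
compound 1, `CCCCCCCCCCCCCCCC(NCc1ccccc1O)=C1C(=O)OC(CO)C1=O`: 24900 nM
compound 2, `CCCCCCCCCCCCCCCC(NCc1cccc(Cl)c1)=C1C(=O)OC(CO)C1=O`: 1430 nM

Among the compounds with values here, compound 2 holds the lower of the two numbers in this assay; its nearest neighbour is compound 1, and the single step between them, a 17-fold lower number from compound 1 to compound 2 (1.24 log units; beyond the scatter), was large. Compound 3, `CCCCCCCCCCCCCCCC(NCc1ccc(C)cc1)=C1C(=O)OC(CO)C1=O`, differs from compound 2 by 4-methylphenyl in place of 3-chlorophenyl on a saturated chain carbon bound to an amine nitrogen. Within the data shown here, only that one measured step bears on the question, and it exchanged a group carrying a hydrogen-bond donor for one without, whereas the change to compound 3 exchanges two groups that both carry no donors and no acceptors. Among the measured compounds shown here, no measured pair shows what the 4-methylphenyl group does here. Compound 3 is therefore expected to stay near compound 2, at most a modest shift toward a higher number, giving an estimated 1.8-fold higher number from compound 2 to compound 3 (0.26 log units; within the scatter). The estimate for compound 3 is 2600 nM, with a range of 900 nM to 7500 nM.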

Compound 3, half-maximal inhibitory concentration: 2680 nM
Compound 3: the middle estimate sits 1.0-fold (0.01 log units) below what was measured; the measured number falls inside the stated range.
By their numbers in this assay, from the lowest: compounds 2 and 3 (each within the scatter of the next); then compound 1.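

In this assay, the exchange of 3-chlorophenyl for 4-methylphenyl on a saturated chain carbon bound to an amine nitrogen gave a 1.9-fold higher number from compound 2 to compound 3 (0.27 log units; within the scatter), so this position accepted two different groups without hydrogen-bond donors or acceptors with no change beyond the scatter. The second reading against the 2-hydroxyphenyl group, a 9.3-fold lower number from compound 1 to compound 3 (0.97 log units; beyond the scatter), shows that the large gap seen with compound 2 was not unique to 3-chlorophenyl, and compound 1 remains above both other compounds. Nothing measured here explains either step.

The compounds shown leave open what a 4-chlorophenyl, a 3-methylphenyl or an unsubstituted phenyl would give, so the effects of the chlorine and the methyl stay tangled with where each sits on the ring. A 2-methoxyphenyl or a 2-aminophenyl group would show whether the low potency of compound 1 belongs to the hydroxyl itself.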